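Methoxycarbonyl in place of acetyl on the ring nitrogen

The source may hold more compounds than are shown below. What is called first, only, known or untested is meant among the compounds shown, and "the series" means these compounds.

Among the compounds with values here, compound 2 `CC(=O)N1C(=O)N(C)C(C)=C(C(=O)NCCCN2CCC(c3ccc(F)cc3)CC2)[C@H]1c1ccc(F)c(F)c1` is the only member of the series with a numerical reading in an in vitro assay on HEK293 cells with Alpha-1D adrenergic receptor (Homo sapiens) as the target; a higher number here means a weaker inhibitor, a lower number a stronger inhibitor; in this assay compound 2 gives 230 nM. Compound 1 `CC1=C(C(=O)NCCCN2CCC(c3ccccn3)CC2)[C@@H](c2ccc(F)c(F)c2)NC(=O)N1` reaches only a limit of this assay, > 5000 nM. That reading is described by the limit of > 5000 nM in this assay, at which 1 of the 2 values shown sits. Compound 1 and compound 2 differ in more than one place, so their two values show nothing more than that one is a number and the other a limit.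

Compound 3 `COC(=O)N1C(=O)N(C)C(C)=C(C(=O)NCCCN2CCC(c3ccc(F)cc3)CC2)[C@H]1c1ccc(F)c(F)c1` differs from compound 2 by methoxy in place of methyl on a carbonyl carbon, which read one bond further out is acetyl to methoxycarbonyl. No measured pair in the series carries a change of this kind, so nothing shown sets the size of the step. The expected step of a 1.1-fold higher number from compound 2 to compound 3 (0.05 log units; within the scatter) is none beyond the usual scatter. Compound 3 is therefore estimated at 260 nM, within a range from 100 nM to 700 nM.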

Compound 3, inhibition constant: 170 nM
Beside the measured number, compound 3's estimate is 1.5-fold (0.18 log units) above it; low and high end bracket the measured number.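

Within the data shown here, on the carbonyl carbon whose other neighbour is the amide-type nitrogen in a ring, methoxy in place of methyl supplies the only readable step: in this assay the change gives a 1.4-fold lower number from compound 2 to compound 3 (0.13 log units; within the scatter) and so sets a first measured size for acetyl to methoxycarbonyl. Within the scatter the two groups read alike, so this place accepts the extra oxygen, a hydrogen-bond acceptor by count, without a shift beyond the usual spread of repeats. Nothing measured here accounts for the step.

From the compounds shown here alone, whether the reading holds with ethoxy or dimethylamino on this carbonyl carbon stays open. Going by these compounds, compound 1 differs from compound 2 and compound 3 in more than one place, so what acetyl or methoxycarbonyl on the ring nitrogen contributes on its own also stays open.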